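The source may report more compounds than this note shows. Statements on the series, on what has been measured and on what is new or still open speak of the compounds shown alone.

In an assay on isolated protein for inhibition of protein deacetylase HDAC6 (Homo sapiens), with a stated time of 60 min (a higher number here means a weaker inhibitor, a lower number a stronger inhibitor), compound 1 `CS(=O)(=O)c1ccc(-n2ccc3cnc(Nc4cnn(CCCCCCC(=O)NO)c4)nc32)cc1` gives 5.9 nM, compound 2 `CS(=O)(=O)c1ccc(-n2ccc3cnc(Nc4cnn(CCCCCC(=O)NO)c4)nc32)cc1` gives 10.8 nM, and compound 3 `O=C(CCCCCn1cc(Nc2ncc3ccn(Cc4ccccc4F)c3n2)cn1)NO` gives 15.3 nM. Compound 2 has the second highest of these three numbers, with compound 3 nearest and compound 1 furthest, yet both steps, a 1.8-fold higher number from compound 1 to compound 2 (0.26 log units; within the scatter) and a 1.4-fold higher number from compound 2 to compound 3 (0.15 log units; within the scatter), lie within the scatter, so compound 2 cannot truly be separated from either neighbour on the numbers shown. Compound 4 `COc1cccc(Cn2ccc3cnc(Nc4cnn(CCCCCC(=O)NO)c4)nc32)c1` has not yet been measured. It differs from compound 2 in one place: 3-methoxybenzyl in place of 4-(methylsulfonyl)phenyl on an aromatic nitrogen. Among the measured compounds shown here, the only measured step that bears on this change is a 1.4-fold higher number from compound 2 to compound 3 (0.15 log units; within the scatter), which also swapped the group on that same aromatic nitrogen and stayed within the scatter. On that single comparison, the step of a 1.3-fold higher number from compound 2 to compound 4 (0.11 log units; within the scatter) is expected to be small, with no direction that can be read beyond the scatter. Compound 4 is therefore estimated at 14 nM in this assay, within a range of 6 nM to 35 nM.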

Compound 4, half-maximal inhibitory concentration: 37.6 nM
Compound 4: the middle estimate sits 2.7-fold (0.43 log units) below what was measured, and the stated range ends below it.
By their numbers in this assay, from the lowest: compounds 1, 2 and 3 (each within the scatter of the next, the first and the last beyond it); then compound 4.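

In this assay, the group on this aromatic nitrogen can no longer be treated as freely exchangeable: 3-methoxybenzyl in place of 4-(methylsulfonyl)phenyl gives a step beyond the scatter (a 3.5-fold higher number from compound 2 to compound 4 (0.54 log units; beyond the scatter)), although 2-fluorobenzyl in the same place did not (a 1.4-fold higher number from compound 2 to compound 3 (0.15 log units; within the scatter)). The benzyl link alone does not settle the outcome, since two benzyl groups also differ beyond the scatter when 3-methoxyphenyl replaces 2-fluorophenyl on the saturated chain carbon bound to that nitrogen (a 2.5-fold higher number from compound 3 to compound 4 (0.39 log units; beyond the scatter)). Nothing available explains these differences.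

The compounds shown leave open whether the step from compound 2 to compound 4 comes from the methoxy group or from the benzyl link, which 3-methoxyphenyl or 4-(methylsulfonyl)benzyl on the same nitrogen could separate. Unsubstituted benzyl, or a benzyl group carrying an amine, also remains open.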